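The source may report more compounds than this note shows. Statements on the series, on what has been measured and on what is new or still open speak of the compounds shown alone.

Measured so far in a functional assay on PC-3M cells (Homo sapiens) for cytotoxicity, read by MTT assay, with a stated time of 48 h; a higher number here means a weaker inhibitor, a lower number a stronger inhibitor:
compound 1, `CCCc1nnc(SC)n1N1C(=O)c2ccccc2C1=O`: > 200000 nM
compound 2, `C=CCSc1nnc(-c2cc(OC)c(OC)c(OC)c2)n1N1C(=O)c2ccccc2C1=O`: > 200000 nM

Both of these readings are limits of this assay, not numbers. Compound 1 reaches only the limit > 200000 nM in this assay. Compound 2 likewise gives only the limit > 200000 nM in this assay. Everything shown for the series sits at that limit (the limit of > 200000 nM in this assay, at which 2 of the 2 values shown sit), so compound 2 stands nowhere in particular among the numbers, as there are none. Among the measured compounds shown here, no step between two measured compounds exists here, and no direction can be read from the data for any change.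

Compound 3, `COc1cc(-c2nnc(SCC(=O)c3ccccc3C)n2N2C(=O)c3ccccc3C2=O)cc(OC)c1OC`, has not been measured. It differs from compound 2 by (2-methylphenyl)carbonyl in place of vinyl on a saturated chain carbon bound to a sulfur. With both measured values at the limit, the expected step is an at least 1.3-fold lower number from compound 2 to compound 3 (0.12 log units; that floor lies within the scatter), most likely none beyond the scatter. Compound 3 is therefore estimated at about 150000 nM, between 40000 nM and 400000 nM, with a fair chance that only a limit is returned.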

Compound 3, half-maximal inhibitory concentration: > 200000 nM
Compound 3: no number, only a limit; the forecaster's own chance of this, stated with the estimate: 65%; middle value at least 1.3-fold (0.12 log units) away from the limit.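

Among the compounds shown here, no step from compound 2 to compound 3 can be read in this assay, and the readings are limits, not numbers: the limit of > 200000 nM in this assay, at which 3 of the 3 values shown sit. The compounds shown leave open whether any change to the groups on the shared core yields a measurable number in this assay.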